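The source may report more compounds than this note shows. Statements on the series, on what has been measured and on what is new or still open speak of the compounds shown alone.

Among the measured compounds shown here, compound 2 `Cc1cc(-c2ccc(F)cc2)c(S(C)(=O)=O)cc1C(=O)N=C(N)N` gives 36 nM in a functional assay for inhibition of sodium/hydrogen exchanger (Oryctolagus cuniculus) (a higher number here means a weaker inhibitor, a lower number a stronger inhibitor), the higher of the two numbers measured so far; compound 1 `CCc1cc(C)c(C(=O)N=C(N)N)cc1S(C)(=O)=O` gives 4.8 nM, and the step of a 7.5-fold higher number from compound 1 to compound 2 (0.88 log units; beyond the scatter) is the only one known. Compound 3 `Cc1cc(-c2cc(Cl)cc(Cl)c2)c(S(C)(=O)=O)cc1C(=O)N=C(N)N` differs from compound 2 by 3,5-dichlorophenyl in place of 4-fluorophenyl on an aromatic carbon. For the measured compounds named here, no measured step exchanges one aryl group for another, so the step from compound 1 to compound 2 bears only loosely on this change. For compound 3 a step within the scatter, or a slight rise, is expected, a 1.4-fold higher number from compound 2 to compound 3 (0.14 log units; within the scatter). Compound 3 is estimated at 50 nM, with a range from 15 nM to 200 nM.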

Compound 3, half-maximal inhibitory concentration: 130 nM
Beside the measured number, compound 3's estimate is 2.6-fold (0.41 log units) below it; the measured number falls inside the stated range.
By their numbers in this assay, from the lowest: compound 1; then compound 2; then compound 3.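

In this assay, swapping one aryl group for another at this position is not neutral: 3,5-dichlorophenyl in place of 4-fluorophenyl gives a further rise (a 3.6-fold higher number from compound 2 to compound 3 (0.56 log units; beyond the scatter)). Against the ethyl group, the gap widens (a 27-fold higher number from compound 1 to compound 3 (1.43 log units; beyond the scatter)), so compound 1 keeps the lowest number and both aryl compounds stand above it. Nothing available explains the difference between the two aryl groups. Open, going by these compounds, is how an unsubstituted phenyl, a 3-chlorophenyl or a 4-chlorophenyl would compare here, which would separate the effect of chlorine from that of the number of ring substituents. Also open, on these data alone, is whether a methyl or propyl group would match ethyl.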